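A few compounds are considered here, and "the series" means these few. Any claim that something is new, unique, unknown or untested is made for them only; others in the source may bear on it.

Measured so far, in a functional assay on HeLa cells (Homo sapiens) for inhibition, read by sulforhodamine B assay, with a stated time of 48 h; on this read-out lower numbers stand for stronger inhibition of growth and higher numbers for weaker inhibition of growth:
Compound 1 `COC(=O)[C@@]1(C)CCC=C2[C@@H]1CC[C@@H](C)[C@]2(C)Cc1c[nH]c2ccccc12` gives 3600 nM.
Compound 2 `COC(=O)[C@@]1(C)CCC=C2[C@@H]1CC[C@@H](C)[C@]2(C)Cc1c[nH]c2ccc(C)cc12` gives 14000 nM.
Compound 3 `COC(=O)[C@@]1(C)CCC=C2[C@@H]1CC[C@@H](C)[C@]2(C)Cc1c[nH]c2ccc(C(F)(F)F)cc12` gives 11000 nM.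

Compound 2 has the highest of the three numbers; compound 3 lies within the scatter of it, while compound 1 stands clearly lower, as the step of a 3.9-fold higher number from compound 1 to compound 2 (0.59 log units; beyond the scatter) shows.

Compound 4 `COC(=O)[C@@]1(C)CCC=C2[C@@H]1CC[C@@H](C)[C@]2(C)Cc1c(C)[nH]c2ccc(C)cc12` differs from compound 2 by methyl in place of hydrogen on an aromatic carbon, on an aromatic carbon of the five-membered ring of the shared core, next to the ring nitrogen.

Two measured steps add a group to an aromatic carbon of the core: a 3.9-fold higher number from compound 1 to compound 2 (0.59 log units; beyond the scatter) and a 3.1-fold higher number from compound 1 to compound 3 (0.49 log units; beyond the scatter), each modest and each raising the number. Neither touches the five-membered ring, so the comparison is loose. A step of similar modest size upward, or none beyond the scatter, is therefore expected in this assay: a 1.4-fold higher number from compound 2 to compound 4 (0.15 log units; within the scatter).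

Compound 4 is estimated at 20000 nM, with a range from 7000 nM to 60000 nM.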

Compound 4, concentration for 50% growth inhibition: 17000 nM
Beside the measured number, compound 4's estimate is 1.2-fold (0.07 log units) above it; low and high end bracket the measured number.
By their numbers in this assay, from the lowest: compound 1; then compounds 3, 2 and 4 (each within the scatter of the next).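

In (this assay), methyl in place of hydrogen on this aromatic carbon of the five-membered ring, next to the ring nitrogen, gives (a 1.2-fold higher number from compound 2 to compound 4 (0.08 log units; within the scatter)), so compound 2 and compound 4 cannot be told apart. The earlier additions, outside this ring, went beyond the scatter, as in (a 3.9-fold higher number from compound 1 to compound 2 (0.59 log units; beyond the scatter)), so at this position a methyl is tolerated in a way those steps did not show. No measurement here explains this contrast. Still open, as far as these compounds go, is whether an amine, a carboxylic acid or a longer chain at this carbon would be tolerated as well. Also open, from the compounds shown here alone, is what the same methyl would do on compound 1.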